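A few compounds are considered here, and "the series" means these few. Any claim that something is new, unique, unknown or untested is made for them only; others in the source may bear on it.

Measured so far in a functional assay on HCT-116 cells (Homo sapiens) for antiproliferative activity, read by CellTiter-Glo, with a stated time of 72 h; a lower number here means a stronger inhibitor, a higher number a weaker inhibitor:

- Compound 1 `O=C(NO)c1ccc(/C=C/c2ccnc(-c3ccc(C(F)(F)F)cc3)c2)cc1` | > 10000 nM (a limit of the assay, not a number)
- Compound 2 `Cc1ccc(-c2cncc(/C=C/c3ccc(C(=O)NO)cc3)c2)c(F)c1` | 2990 nM

Among the compounds with values here, compound 2 holds the only true number, at 2990 nM. Compound 1 sits at the limit of > 10000 nM and gives no number to compare against.

Next is compound 3 `COc1ccc(F)cc1-c1cncc(/C=C/c2ccc(C(=O)NO)cc2)c1`, which carries 5-fluoro-2-methoxyphenyl in place of 2-fluoro-4-methylphenyl (5-fluoro-2-methoxyphenyl in place of 2-fluoro-4-methylphenyl on an aromatic carbon). The swap falls on an aromatic carbon of a six-membered aromatic ring with 1 nitrogen, two atoms from the ring nitrogen and meta to a large group. The rest of the structure stays as in compound 2.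

Within the data shown here, no measured pair differs in one place only, so the size of this step in this assay has no direct precedent. The expectation therefore starts from compound 2 at 2990 nM and assumes no clear shift in either direction. The estimated 1.2-fold lower number from compound 2 to compound 3 (0.08 log units; within the scatter) is expected to stay within the usual scatter of the assay.

For compound 3 the expected value is 2500 nM, with an estimated range of 800 nM to 8000 nM.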

Compound 3, half-maximal inhibitory concentration: 3410 nM
Estimate against measurement, compound 3: 1.4-fold (0.13 log units) below, within the range that was stated.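

In this assay, placing 5-fluoro-2-methoxyphenyl in place of 2-fluoro-4-methylphenyl, on an aromatic carbon two atoms from the ring nitrogen and meta to a large group, gives a 1.1-fold higher number from compound 2 to compound 3 (0.06 log units; within the scatter). Within the data shown here, this is the only readable step, and it shows that this exchange of one substituted phenyl for another, which brings in a methoxy oxygen counted as a hydrogen-bond acceptor, leaves the number unchanged within the scatter. Compound 1 remains a limit of the assay and not a number, so no step to it can be read: the limit of > 10000 nM in this assay, at which 1 of the 3 values shown sits.

Going by these compounds, both groups compared at this position are phenyl rings carrying a fluorine, so the response to an unsubstituted phenyl, or to a group of another kind such as an amine or a carboxylic acid, remains open. Among these compounds, also open is whether any change at this position can move the number beyond the scatter, since the one readable step does not.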